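Trimming an Amine Substituent on a Shared Kinase Scaffold

A few compounds are considered here, and "the series" means these few. Any claim that something is new, unique, unknown or untested is made for them only; others in the source may bear on it.

Of the compounds shown here, two built on the same core have been tested in an assay on isolated protein for inhibition of NUAK family SNF1-like kinase 1 (Homo sapiens), read by ADP-Glo, with a stated time of 60 min, tested at 10 uM, in the presence of a further agent that is not named here; on this read-out higher numbers stand for more inhibition at the one concentration tested (going by the name of the read-out) and lower numbers for less inhibition. In this assay compound 1 `CCC(=O)Nc1cccc(Oc2nc(Nc3ccc(N(C)C)cc3OC)ncc2Cl)c1` gives 80.6%. Compound 2 `CCC(=O)Nc1cccc(Oc2nc(Nc3ccc(N(CC)CC)cc3)ncc2Cl)c1` gives 54.4% in this assay, the lower of the two numbers, and the gap to compound 1 lies beyond the usual scatter of repeated measurements. Compound 3 `CCC(=O)Nc1cccc(Oc2nc(Nc3ccc(N(C)C)cc3)ncc2Cl)c1` has not yet been measured. It differs from compound 2 in a single place: dimethylamino in place of diethylamino on an aromatic carbon. For the measured compounds named here, no measured pair shows exactly this change, so its effect cannot be read from the data at hand. Compound 1 also carries a dimethylamino group, though with a further difference in its structure, and it stands higher than compound 2. A modest upward step is therefore expected, a number 7.6 percentage points higher from compound 2 to compound 3 (within the scatter), with considerable uncertainty. Compound 3 is estimated to reach 62% in this assay, within an expected range from 42% to 80%.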

Compound 3, a percentage reported as inhibition, at one concentration (the size of the read-out at that concentration, not a potency): 72.6%
The estimate for compound 3 lay 10.6 percentage points below the measured number; the range from low to high includes it.
By their numbers in this assay, from the lowest: compound 2; then compounds 3 and 1 (each within the scatter of the next).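

Swapping diethylamino for dimethylamino on the aromatic carbon, para to a large group, now has a direct comparison: the step is a number 18.2 percentage points higher from compound 2 to compound 3 (beyond the scatter) in this assay, so this change alone moves the result by more than the usual scatter. The second comparison gives a number 8 percentage points lower from compound 1 to compound 3 (within the scatter), which means that the methoxy group of compound 1 is not required for a number at this level when dimethylamino is present. Nothing available explains why the shorter amine substituent gives more inhibition.

On these data alone, two amine substituents cannot define a trend, so it remains open how a methylamino group, an unsubstituted amine or a morpholine ring would behave at this position. As far as these compounds go, it is also open whether a methoxy group would change the result for the diethylamino compound, or whether a fluorine would differ from hydrogen at the methoxy position.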